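Cytotoxicity Outlook for a 4-Chlorophenyl Amide Analogue

The compounds below may be only part of what the source reports. "The series", "measured", "known", "first", "only" and "open" are said of these compounds alone.

Three measured compounds share one core and differ only in the group on a terminal amine nitrogen. Compound 1 `Cc1ccc(S(=O)(=O)N[C@@H](CC(=O)NC(C)(C)C)C(=O)NCCNS(=O)(=O)c2ccccc2)cc1` carries a phenylsulfonyl there. In an ADME assay on HepG2 cells (Homo sapiens) for cytotoxicity (a lower number here means that less compound is needed, a higher number that more compound is needed for the effect), compound 1 gives > 11000 nM, a limit of the assay rather than a number. Compound 2 `Cc1ccc(S(=O)(=O)N[C@@H](CC(=O)NC(C)(C)C)C(=O)NCCNC(=O)c2ccccc2F)cc1` carries a (2-fluorophenyl)carbonyl in the same place. In this assay compound 2 gives > 11000 nM, again a limit and not a number. Compound 3 `Cc1ccc(S(=O)(=O)N[C@@H](CC(=O)NC(C)(C)C)C(=O)NCCNC(=O)c2cc(C)ccn2)cc1` carries a (4-methylpyridin-2-yl)carbonyl. In this assay compound 3 gives > 11000 nM, also a limit. Among the measured compounds shown here, because of the limit of > 11000 nM in this assay, at which 3 of the 3 values shown sit, no step between them can be read: a step that the two limits leave unreadable from compound 1 to compound 2, a step that the two limits leave unreadable from compound 1 to compound 3 and a step that the two limits leave unreadable from compound 2 to compound 3 are all of unknown size. Compound 2 thus stands exactly where every measured value stands, at the limit.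

Compound 4 `Cc1ccc(S(=O)(=O)N[C@@H](CC(=O)NC(C)(C)C)C(=O)NCCNC(=O)c2ccc(Cl)cc2)cc1` is not yet measured. It differs from compound 2 in this way: 4-chlorophenyl in place of 2-fluorophenyl on a carbonyl carbon. The measured steps exchanging one group in that region bear on this change, but none has a readable size, so no direction can be taken from them; what is known is that each change tried so far left the value at the limit. The step expected from compound 2 to compound 4 in this assay is a step that the limit leaves unreadable from compound 2 to compound 4, none beyond the scatter. Compound 4 is estimated at 15000 nM, between 5000 nM and 50000 nM, most likely reported again only as a limit.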

Compound 4, half-maximal effective concentration: > 11000 nM
Compound 4: a limit, no number; the forecaster's own chance of this, stated with the estimate: 85%; the middle value is on the limit's open side.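

In this assay compound 4 gives > 11000 nM as a limit of the assay and not a number. Among the compounds shown here, no new step linking compound 4 with compound 1, compound 2 or compound 3 can be read: the limit of > 11000 nM in this assay, at which 4 of the 4 values shown sit. The compounds shown leave open whether any group on the terminal amine nitrogen would give a readable number in this assay at all.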